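This account rests on a few compounds, and the source may have more. Where it says the series, first, only, none or still open, it means among the compounds named here.

In a physicochemical assay for solubility, measured as kinetic solubility (on this read-out lower numbers stand for lower solubility and higher numbers for higher solubility), compound 1 (`CC(=O)Nc1cc(-c2cnc(N(C)C(=O)c3c(F)cccc3Cl)c(N3CC4CC4C3)c2)n(C(C)C)n1`) reads 48 ug/mL and compound 3 (`CN(C(=O)c1c(F)cccc1Cl)c1ccc(-c2cc(C(N)=O)ccc2Cl)cc1OCC(F)(F)F`) reads 0.3 ug/mL while compound 2 (`CC(=O)Nc1cc(-c2ccc(N(C)C(=O)c3c(F)cccc3Cl)c(N3CC4CC4C3)c2)n(C2CCC2)n1`) reads 0.5 ug/mL and so sits within the scatter of compound 3 and far under compound 1. Compound 4 (`CC(=O)Nc1cc(-c2ccc(N(C)C(=O)c3c(F)cccc3Cl)c(N3CC4CC4C3)c2)n(CC(C)(C)C)n1`) is not yet measured. It carries neopentyl in place of cyclobutyl on an aromatic nitrogen and otherwise matches compound 2. Among the measured compounds shown here, no measured pair differs in one place only, so no measured step gauges this change directly. The expectation therefore starts from compound 2 at 0.5 ug/mL as the only close reference. The expected move is a 1.3-fold lower number from compound 2 to compound 4 (0.10 log units; within the scatter) and would stay within the scatter, with no firm direction. Compound 4 is estimated at 0.4 ug/mL with an expected range from 0.15 ug/mL to 1.5 ug/mL as the working figure.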

Compound 4, solubility: 0.8 ug/mL
Beside the measured number, compound 4's estimate is 2.0-fold (0.30 log units) below it; low and high end bracket the measured number.
By their numbers in this assay, from the lowest: compounds 3, 2 and 4 (each within the scatter of the next, the first and the last beyond it); then compound 1.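

In this assay, among the compounds shown here, neopentyl in place of cyclobutyl on the aromatic nitrogen gives a 1.6-fold higher number from compound 2 to compound 4 (0.20 log units; within the scatter) and is the first direct reading at this position. Between these two carbon-only groups, losing the four-membered ring leaves the read-out within the scatter, so this one swap gives no firm direction. No measurement on hand bears on why the two groups read alike. Still open, going by these compounds, is whether a methyl group, a hydroxyethyl chain or an aminoethyl chain on this nitrogen would read apart from cyclobutyl and neopentyl.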